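This account rests on a few compounds, and the source may have more. Where it says the series, first, only, none or still open, it means among the compounds named here.

Compound 1 `O=c1cc(CSC(=S)N2CCCC2)oc2cc(Cl)ccc12` and compound 2 `CC(C)N(C(=S)SCc1cc(=O)c2ccc(Cl)cc2o1)C(C)C` share one core, while compound 3 `Cc1ccc2c(=O)c(CSC(=S)N3CCCC3)coc2c1` sits on a core whose difference from the core of compound 1 is not broken down here. In a functional assay on MDA-MB-435S cells (Homo sapiens) for antiproliferative activity, read by MTT assay, with a stated time of 72 h (a lower number here means a stronger inhibitor, a higher number a weaker inhibitor), compound 1 gives > 25000 nM, which is a limit of the assay. In this assay compound 2 gives > 25000 nM, again a limit. The step that the two limits leave unreadable from compound 1 to compound 2 is therefore unreadable, as both values rest at the limit of > 25000 nM in this assay, at which 2 of the 3 values shown sit; the change itself is diisopropylamino in place of pyrrolidin-1-yl on a thiocarbonyl carbon. In this assay, among the compounds with values here, compound 3 gives 1900 nM, the only number among the three. Compound 4 `Cc1ccc2c(=O)c(CSC(=S)N(C(C)C)C(C)C)coc2c1` carries the same change, (diisopropylamino in place of pyrrolidin-1-yl on a thiocarbonyl carbon), at a place described in the same words, so it is the same change. Nothing measured fixes its size. The step from compound 3 to compound 4 is expected near neutral, a 1.6-fold higher number from compound 3 to compound 4 (0.20 log units; within the scatter), and compound 4 is estimated at 3000 nM in this assay.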

Compound 4, half-maximal inhibitory concentration: 240 nM
The estimate for compound 4 lay 13-fold (1.10 log units) above the measured number; measured number below the stated range.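

On the core of compound 3, diisopropylamino in place of pyrrolidin-1-yl on a thiocarbonyl carbon gives a 7.9-fold lower number from compound 3 to compound 4 (0.90 log units; beyond the scatter) in this assay. On the core of compound 1, the same change cannot be read, as compound 1 and compound 2 both rest at a limit of the assay: the limit of > 25000 nM in this assay, at which 2 of the 4 values shown sit.

The change therefore has a readable size on one core only, and the series neither shows that this size carries to the core of compound 1 nor shows that it fails to carry.

Open, on these data alone, is whether diethylamino or morpholin-4-yl on that thiocarbonyl carbon of the core of compound 3 would give a number nearer compound 3 or compound 4.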